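Amine variation on the propoxy chain of the shared core

The source may hold more compounds than are shown below. What is called first, only, known or untested is meant among the compounds shown, and "the series" means these compounds.

Within the data shown here, compound 2 `CCCCc1sc(-c2ccc(OCCCN(CC)CC)cc2)nc1-c1ccc(Oc2ccc(Cl)cc2)cc1` gives 58.9% in an assay on isolated protein for antagonist activity at advanced glycosylation end product-specific receptor (Homo sapiens), read by ELISA, with a stated time of 60 min, tested at 10 uM (a lower number here means less inhibition, a higher number more inhibition at the concentration tested (going by the name of the read-out)), the highest of the two numbers so far; compound 1 `CCCCc1sc(-c2ccc(OCCCN3CCCC3)cc2)nc1-c1ccc(Oc2ccc(Cl)cc2)cc1` gives 47.8%. Among the measured compounds shown here, the only step so far, a number 11.1 percentage points higher from compound 1 to compound 2 (beyond the scatter), concerns the same amine position. Compound 3 `CCCCc1sc(-c2ccc(OCCCN(C)C)cc2)nc1-c1ccc(Oc2ccc(Cl)cc2)cc1` carries dimethylamino in place of diethylamino on a saturated chain carbon, three bonds along the chain from an oxygen on an aromatic ring. For the measured compounds named here, no measured step matches this change; the one step known touches the same place but a different pair of groups, so its size is only a loose guide. A step no larger than the scatter, probably slightly downward, is expected, a number 6.9 percentage points lower from compound 2 to compound 3 (within the scatter). Compound 3 is estimated at 52%, within 35% to 70%.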

Compound 3, a percentage reported as inhibition, at one concentration (the size of the read-out at that concentration, not a potency): 46.2%
Compound 3: the middle estimate sits 5.8 percentage points above what was measured; the measured number falls inside the stated range.
By their numbers in this assay, from the lowest: compounds 3 and 1 (each within the scatter of the next); then compound 2.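

In this assay dimethylamino in place of diethylamino gives a number 12.7 percentage points lower from compound 2 to compound 3 (beyond the scatter) and leaves diethylamino with the highest number of the three amines. Dimethylamino in place of pyrrolidin-1-yl gives a number 1.6 percentage points lower from compound 1 to compound 3 (within the scatter) and does not separate those two amines, so only diethylamino stands apart here. Nothing at hand accounts for this gap.

Open, from the compounds shown here alone, is whether dipropylamino on the same chain carbon would extend the rise seen with diethylamino. Also open, going by these compounds, is how a piperidin-1-yl or morpholin-4-yl group would compare at this place.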